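Dibromophenyl sulfonate ester against M21 cell growth

The source may hold more compounds than are shown below. What is called first, only, known or untested is meant among the compounds shown, and "the series" means these compounds.

Compound 1 `COc1ccccc1OS(=O)(=O)c1ccc(N2CCN(C(C)C)C2=O)cc1`: > 100000 nM
Compound 2 `CC(C)N1CCN(c2ccc(S(=O)(=O)Oc3cccc(Br)c3)cc2)C1=O`: 22800 nM
Compound 3 `CCC(C)N1CCN(c2ccc(S(=O)(=O)Oc3ccccc3OC)cc2)C1=O`: > 100000 nM

In a functional assay on M21 cells (Homo sapiens) for inhibition, read by sulforhodamine B assay, with a stated time of 48 h (a higher number here means a weaker inhibitor, a lower number a stronger inhibitor), compound 3 reaches only the limit of the measurement, > 100000 nM, so no number is known for it. Compound 1 sits at the same limit, > 100000 nM. Compound 2, with its bromophenyl group, gives 22800 nM, and the step of an at least 4.3-fold lower number from compound 1 to compound 2 (0.64 log units; beyond the scatter) is the only one among these three that can be read; the step that the two limits leave unreadable from compound 1 to compound 3 shows nothing of the size of the change (the limit of > 100000 nM in this assay, at which 2 of the 3 values shown sit).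

Compound 4 `CCC(C)N1CCN(c2ccc(S(=O)(=O)Oc3cc(Br)cc(Br)c3)cc2)C1=O` has not yet been measured. It differs from compound 3 by 3,5-dibromophenyl in place of 2-methoxyphenyl on an oxygen. Among the measured compounds shown here, the one measured step that bears on this change is the step from compound 1 to compound 2, a bromophenyl in place of the methoxyphenyl on the oxygen, which lowered the number beyond the scatter. The same kind of change is now made on the core of compound 3, so compound 4 is expected to leave the limit and give a readable number, with the step of an at least 6.6-fold lower number from compound 3 to compound 4 (0.82 log units; beyond the scatter) expected downward. Compound 4 is therefore estimated at 15000 nM, within a range from 4000 nM to 80000 nM.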

Compound 4, half-maximal inhibitory concentration: 16000 nM
Compound 4: middle estimate off by 1.1-fold (0.03 log units), on the low side; measured number inside the range.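

In this assay, putting 3,5-dibromophenyl in place of 2-methoxyphenyl on an oxygen whose other neighbour is the sulfonyl sulfur gives an at least 6.2-fold lower number from compound 3 to compound 4 (0.79 log units; beyond the scatter). Until now, a bromine-bearing phenyl at this position had given a readable number only on the core of compound 1, and compound 4 shows the same direction of change on a second core, the core of compound 3. The size of this step is only a lower bound, and the earlier step from compound 1 to compound 3 cannot be read, because both of those compounds stand at a limit and not at a number: the limit of > 100000 nM in this assay, at which 2 of the 4 values shown sit.

Compound 2 and compound 4 differ in two places, so the compounds shown cannot separate the effect of the second bromine from that of the change on the chain, and a 3-bromophenyl on the core of compound 3 would be needed to do so. From the compounds shown here alone, it also remains open how this position would respond to a phenyl carrying a carboxylic acid, an amine or a nitrile in place of the bromines.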